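The source may hold more compounds than are shown below. What is called first, only, known or untested is meant among the compounds shown, and "the series" means these compounds.

Measured so far:
compound 1 `COc1ccc(S(=O)(=O)N2CCc3cccc(NC(=O)c4ccc([N+](=O)[O-])cc4)c32)cc1` – 95 nM
compound 2 `COc1ccc(S(=O)(=O)N2CCc3cc(Br)cc(NC(=O)c4ccco4)c32)cc1` – 78 nM
compound 3 `COc1ccc(S(=O)(=O)N2CCc3cccc(NCc4ccccc4)c32)cc1` – > 10000 nM

In a functional assay on MKN-45 cells (Homo sapiens) for cytotoxicity (on this read-out lower numbers stand for stronger inhibition and higher numbers for weaker inhibition), compound 1 gives 95 nM, the higher of the two numbers in hand, but the gap to compound 2 at 78 nM lies within the scatter, so the two cannot be set apart. For compound 3 this assay reports only a limit, > 10000 nM (the limit of > 10000 nM in this assay, at which 1 of the 3 values shown sits). Compound 3 carries no amide carbonyl; both compounds with a number carry one.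

The step of interest goes from compound 1 to compound 4 `COc1ccc(S(=O)(=O)N2CCc3cccc(NC(=O)c4ccco4)c32)cc1`: furan-2-yl in place of 4-nitrophenyl on a carbonyl carbon. Compound 4 shares the furan-2-yl amide with compound 2 and the unsubstituted core with compound 1. Among the measured compounds shown here, no measured step separates these two points, so no size is computed for it.

Expectation: compound 4 is expected to fall close to compound 1, because compound 2, which already carries the furan-2-yl amide, gives 78 nM. The step from compound 1 to compound 4 is expected at a 1.4-fold higher number from compound 1 to compound 4 (0.14 log units; within the scatter), within the scatter. Compound 4 is estimated at 130 nM, with a range from 50 nM to 400 nM.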

Compound 4, half-maximal inhibitory concentration: 10.7 nM
Compound 4: middle estimate off by 12-fold (1.08 log units), on the high side, and the stated range ends above it.
By their numbers in this assay, from the lowest: compound 4; then compounds 2 and 1 (each within the scatter of the next). At a limit, above all of these: compound 3.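

In this assay, furan-2-yl in place of 4-nitrophenyl on a carbonyl carbon gives an 8.9-fold lower number from compound 1 to compound 4 (0.95 log units; beyond the scatter), so the group on the carbonyl carbon matters in a way the indistinguishable numbers of compounds 1 and 2 did not reveal. Hydrogen in place of bromo on an aromatic carbon gives a 7.3-fold lower number from compound 2 to compound 4 (0.86 log units; beyond the scatter), which shows that the bromo-bearing compound 2 also gives up potency against compound 4. The step with (furan-2-yl)carbonyl in place of benzyl on a nitrogen on an aromatic ring is an at least 930-fold lower number from compound 3 to compound 4 (2.97 log units; beyond the scatter), and its size rests on a limit for compound 3: the limit of > 10000 nM in this assay, at which 1 of the 4 values shown sits.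

Open, going by these compounds, is whether thiophen-2-yl or unsubstituted phenyl on the carbonyl carbon would keep a number near that of compound 4. Also open, on these data alone, is whether the bromo step keeps its size with 4-nitrophenyl on the carbonyl carbon, and whether chloro or methoxy at that aromatic carbon behaves like bromo.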